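This account rests on a few compounds, and the source may have more. Where it says the series, first, only, none or still open, it means among the compounds named here.

For the measured compounds named here, compound 1 `Cc1ccc(Oc2c(/C=N\OCc3c(Cl)c(-c4ccc(Cl)cc4)nn3C)c(C)nn2C)cc1` carries the one full number here: in a functional assay on SMMC-7721 cells (Homo sapiens) for inhibition, read by MTT assay, with a stated time of 72 h, tested at 25 uM (on this read-out lower numbers stand for less inhibition and higher numbers for more inhibition at the one concentration tested (going by the name of the read-out)), compound 1 gives 80%. Compound 2 `CCc1nn(C)c(CO/N=C\c2c(C)nn(C)c2Oc2ccc(OC(F)(F)F)cc2)c1Cl` gives < 80% in this assay, a limit rather than a number; where it stands is shown by the limit of < 80% in this assay, at which 1 of the 2 values shown sits. Compound 3 `Cc1nn(C)c(Oc2ccc(OC(F)(F)F)cc2)c1/C=N\OCc1c(Cl)c(-c2ccc(Cl)cc2)nn1C` is not yet measured. It differs from compound 2 by 4-chlorophenyl in place of ethyl on an aromatic carbon. No measured step sizes this change, so only an expectation is possible: a rise beyond the scatter is expected, a step that the limit leaves unreadable from compound 2 to compound 3. Compound 3 is accordingly estimated at 68%, with a likely range from 40% to 85%.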

Compound 3, a percentage reported as inhibition, at one concentration (the size of the read-out at that concentration, not a potency): 80%
Compound 3: middle estimate off by 12 percentage points, on the low side, within the range that was stated.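

Compound 3, with 4-chlorophenyl on the aromatic carbon, has a full number in this assay, whereas compound 2, with ethyl there, has only a limit: the limit of < 80% in this assay, at which 1 of the 3 values shown sits.

The change from ethyl to 4-chlorophenyl therefore has a direction at most, with a number no lower from compound 2 to compound 3 (the limit leaves the size open), and its size cannot be read. With 4-chlorophenyl kept, trifluoromethoxy in place of methyl on an aromatic carbon gets its first reading, with no change at the digits printed from compound 1 to compound 3 (within the scatter).

From the compounds shown here alone, how far compound 2 actually lies from its limit remains open, and with it whether the 4-chlorophenyl matters at all. Also open, going by these compounds, is how an amine or a carboxylic acid would read at that place.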